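A few compounds are considered here, and "the series" means these few. Any claim that something is new, unique, unknown or untested is made for them only; others in the source may bear on it.

In a functional assay on MCF7 cells (Homo sapiens) for antiproliferative activity, read by MTT assay, with a stated time of 48 h (a lower number here means a stronger inhibitor, a higher number a weaker inhibitor), compound 1 `N#CC1=C(N)Oc2c(c3nc4ccccc4nc3c3ccccc23)C12C(=O)N(Cc1cnnn1-c1ccc(F)cc1)c1ccccc12` gives > 50000 nM, which is a limit of the assay rather than a number. Compound 2 `N#CC1=C(N)Oc2c(c3nc4ccccc4nc3c3ccccc23)C12C(=O)N(Cc1cnnn1-c1cccc(Cl)c1)c1ccccc12` gives 43600 nM in this assay. Compound 3 `N#CC1=C(N)Oc2c(c3nc4ccccc4nc3c3ccccc23)C12C(=O)N(Cc1cnnn1-c1ccc([N+](=O)[O-])cc1)c1ccccc12` gives > 50000 nM, again a limit of the assay. Compound 3 therefore stands at the limit of > 50000 nM in this assay, at which 2 of the 3 values shown sit, and its position can be told only as that limit. Compound 4 `Cc1ccc(-n2nncc2CN2C(=O)C3(C(C#N)=C(N)Oc4c3c3nc5ccccc5nc3c3ccccc43)c3ccccc32)c(C)c1` differs from compound 3 by 2,4-dimethylphenyl in place of 4-nitrophenyl on an aromatic nitrogen. The measured steps that bear on this change are an at least 1.1-fold higher number from compound 2 to compound 3 (0.05 log units; that floor lies within the scatter) and a step that the two limits leave unreadable from compound 1 to compound 3; neither yields a readable size. The account therefore expects no step beyond the scatter in this assay for compound 4. For compound 4 the estimate is 50000 nM, with a range from 20000 nM to 120000 nM, which is expected to mean a number no higher from compound 3 to compound 4 (the limit leaves the size open).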

Compound 4, half-maximal inhibitory concentration: > 50000 nM
Compound 4: no number, only a limit; the forecaster's own chance of this, stated with the estimate: 70%; the middle value lies on the limit itself.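

In this assay, compound 4 carries 2,4-dimethylphenyl, with 0 hydrogen-bond acceptors, on the aromatic nitrogen, and it still ends at a limit of the assay, as compound 3 does with 4-nitrophenyl, which has 2 hydrogen-bond acceptors. Within the data shown here, the one readable step is an at least 1.1-fold higher number from compound 2 to compound 4 (0.05 log units; that floor lies within the scatter); the other steps to compound 4 cannot be read. The values at this position now gather at one point: the limit of > 50000 nM in this assay, at which 3 of the 4 values shown sit.

Going by these compounds, how a benzyl group, a carboxylic acid or a longer alkyl chain on this aromatic nitrogen would read in this assay remains open. So does whether any group there gives a clear number at all.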